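The source may report more compounds than this note shows. Statements on the series, on what has been measured and on what is new or still open speak of the compounds shown alone.

Measured so far:
compound 1, `CC1CCN(c2c(S(=O)(=O)c3ccc(F)c(F)c3)cnc3cc(Cl)ccc23)CC1`: 90%
compound 2, `CC1CCN(c2c(S(=O)(=O)c3cccc(C#N)c3)cnc3cc(Cl)ccc23)CC1`: 94%

For the measured compounds named here, of the two numbers so far in an assay on isolated protein for displacement of a labelled ligand from metabotropic glutamate receptor 5 (Homo sapiens), with a stated time of 60 min, tested at 1 uM (on this read-out higher numbers stand for more inhibition at the one concentration tested (going by the name of the read-out) and lower numbers for less inhibition), compound 2 stands at the top, but its only neighbour is compound 1, and the step of a number 4 percentage points higher from compound 1 to compound 2 (within the scatter) lies within the scatter, so the two compounds cannot be told apart on these data. Compound 3, `COc1ccc(S(=O)(=O)c2cnc3cc(Cl)ccc3c2N2CCC(C)CC2)cc1OC`, has not yet been measured. It differs from compound 2 in one place: 3,4-dimethoxyphenyl in place of 3-cyanophenyl on a sulfonyl sulfur. Going by the values given here, the one measured step that bears on this is an exchange of the same kind, one aryl group for another on the sulfonyl sulfur, namely a number 4 percentage points higher from compound 1 to compound 2 (within the scatter), which produced nothing beyond the scatter. Among the compounds with values here, on that basis the step of a number 8 percentage points lower from compound 2 to compound 3 (within the scatter) is expected to be small, with no clear direction; since only a single comparable step is known, the range must stay wide. Compound 3 is therefore expected to give 86% in this assay, between 60% and 97%.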

Compound 3, a percentage reported as inhibition, at one concentration (the size of the read-out at that concentration, not a potency): 93%
For compound 3 the middle estimate is 7 percentage points below the measured one; the measured number falls inside the stated range.
By their numbers in this assay, from the lowest: compounds 1, 3 and 2 (each within the scatter of the next).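

In this assay the entering 3,4-dimethoxyphenyl group gives a number 1 percentage points lower from compound 2 to compound 3 (within the scatter) and, set against the 3,4-difluorophenyl compound, a number 3 percentage points higher from compound 1 to compound 3 (within the scatter). Three aryl groups on the sulfonyl sulfur now cannot be told apart, even though the entering group has more heavy atoms than 3-cyanophenyl, carries oxygen instead of nitrogen and has no triple bond. No measurement shown explains this sameness.

Going by these compounds, all three groups are six-membered carbon aromatic rings, so it remains open whether a group of another kind on the sulfonyl sulfur, such as an amine or a short alkyl chain, would give a similar number. On these data alone, the read-out comes from a single concentration and is not a potency, so real differences in potency among the three compounds also remain open.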